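The source may hold more compounds than are shown below. What is called first, only, known or untested is meant among the compounds shown, and "the series" means these compounds.

Working notes on the series, values in a functional assay on NCI-H460 cells (Homo sapiens) for antiproliferative activity; on this read-out lower numbers stand for stronger inhibition of growth and higher numbers for weaker inhibition of growth:

- compound 1 `Cc1ccnc2nc(-c3cccc(Cl)c3)cc(O)c12`: 38.9 nM
- compound 2 `Cc1ccc2c(O)cc(-c3cccc(Cl)c3)nc2n1`: 41.7 nM

Among the measured compounds shown here, with only two measured compounds, the series gives a narrow picture. Compound 2, at 41.7 nM, lies within the scatter of compound 1, at 38.9 nM, so the two cannot be ranked. For the measured compounds named here, no measured pair differs in one place, so the size of the next step has no direct precedent.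

The next compound to be tested is compound 3 `Cc1cccc(-c2cc(O)c3ccc(C)nc3n2)c1`, which has methyl in place of chloro on an aromatic carbon. The swap sits on a six-membered aromatic ring of carbon only, meta to a large group, and the rest of the structure is unchanged.

In this assay, a small move toward weaker growth inhibition is expected, and it may not exceed the scatter. The expected change is a 1.3-fold higher number from compound 2 to compound 3 (0.12 log units; within the scatter), an estimate that carries wide uncertainty. The estimate for compound 3 is 55 nM, with an expected range of 18 nM to 170 nM.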

Compound 3, concentration for 50% growth inhibition: 17.8 nM
For compound 3 the middle estimate is 3.1-fold (0.49 log units) above the measured one, and the stated range ends above it.
By their numbers in this assay, from the lowest: compound 3; then compounds 1 and 2 (each within the scatter of the next).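

In this assay, among the compounds shown here, methyl in place of chloro gives a 2.3-fold lower number from compound 2 to compound 3 (0.37 log units; beyond the scatter), the first step that can be read, and a modest one. It shows that this place, on a six-membered aromatic ring of carbon only and meta to a large group, is not indifferent to its substituent: two groups of one heavy atom each, both with no hydrogen-bond donors, no hydrogen-bond acceptors and no net charge, are told apart on this read-out, with methyl on the side of stronger inhibition of growth. No measurement at hand accounts for the step.

A single step does not show whether an ethyl group, a methoxy group or an amine at the same place would move the number further in this direction or reverse it, nor what plain hydrogen there would give. As far as these compounds go, whether the same swap would give a step of similar size on the core of compound 1 also remains open.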